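The source may hold more compounds than are shown below. What is called first, only, known or untested is meant among the compounds shown, and "the series" means these compounds.

Measured so far:
compound 1, `COc1cc(Cl)cc(-c2nn(-c3cccc(NC(=O)Nc4ccc(Cl)c(Cl)c4)c3)cc2-c2ccncc2)c1` — 101%
compound 2, `COc1cc(Cl)cc(-c2nn(-c3cccc(NC(=O)Nc4cccc(C(F)(F)F)c4)c3)cc2-c2ccncc2)c1` — 99%

In a functional assay on NCI-H322M cells (Homo sapiens) for inhibition, read by sulforhodamine B assay, with a stated time of 48 h, tested at 0.01 uM (a higher number here means a weaker effect of the compound at the concentration tested, a lower number a stronger effect), compound 1 gives 101% and compound 2 gives 99%. For the measured compounds named here, the one measured step, a number 2 percentage points lower from compound 1 to compound 2 (within the scatter), changes the aryl group on the urea nitrogen and leaves the read-out essentially where it was. Compound 2 stands at the lower of the two numbers, but its neighbour compound 1 lies within the scatter, so no order between them can be claimed.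

Compound 3, `COc1cc(Cl)cc(-c2nn(-c3cccc(NC(=O)c4cccc(C(F)(F)F)c4)c3)cc2-c2ccncc2)c1`, differs from compound 2 in one place: 3-(trifluoromethyl)phenyl in place of (3-(trifluoromethyl)phenyl)amino on a carbonyl carbon. The urea thus becomes an amide, with the same aryl group retained. Going by the values given here, no measured step touches this part of the molecule, so the only bearing comes from the pair above, where changing the aryl group made no difference beyond the scatter. The estimated step of no change at the digits printed from compound 2 to compound 3 (within the scatter) is therefore expected to stay within the scatter. For compound 3 the expected value in this assay is 99%, with a range from 88% to 108%.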

Compound 3, a percentage reported as activity, at one concentration (the size of the read-out at that concentration, not a potency): 69%
The estimate for compound 3 lay 30 percentage points above the measured number; measured number outside the range, below it.
By their numbers in this assay, from the lowest: compound 3; then compounds 2 and 1 (each within the scatter of the next).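

In this assay, for the compounds shown here, the read-out responds to the link between the aryl group and the carbonyl carbon, which the aryl change among the ureas did not show: removing the amino nitrogen, with 3-(trifluoromethyl)phenyl in place of (3-(trifluoromethyl)phenyl)amino, gives a number 30 percentage points lower from compound 2 to compound 3 (beyond the scatter) as the first step to clear the scatter. The comparison with the other urea, where the aryl group changes as well, gives a number 32 percentage points lower from compound 1 to compound 3 (beyond the scatter) and points the same way, so both ureas stand apart from the amide. No measurement available here accounts for this shift.

On these data alone, with a single amide carrying the result, it remains open whether 3,4-dichlorophenyl on the carbonyl carbon would read like compound 3. Also open, as far as these compounds go, is what a methylene or a sulfonamide in this link would give.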